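A few compounds are considered here, and "the series" means these few. Any claim that something is new, unique, unknown or untested is made for them only; others in the source may bear on it.

Measured in a functional assay on HL-60 cells (Homo sapiens) for inhibition, read by CCK-8 assay, with a stated time of 48 h; a lower number here means a stronger inhibitor, a higher number a weaker inhibitor:
compound 1 `O=C(NCCNS(=O)(=O)c1ccc(-c2ccccc2O[C@H]2CC[C@H](O)CC2)s1)Nc1cc(C(F)(F)F)cc(C(F)(F)F)c1`: 7100 nM
compound 2 `O=C(NCCNS(=O)(=O)c1ccc(-c2ccccc2OCc2cccc(O)c2)s1)Nc1cc(C(F)(F)F)cc(C(F)(F)F)c1`: 4000 nM
compound 3 `O=C(NCCNS(=O)(=O)c1ccc(-c2ccccc2Oc2ccc([N+](=O)[O-])c([N+](=O)[O-])c2)s1)Nc1cc(C(F)(F)F)cc(C(F)(F)F)c1`: 1900 nM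

Compound 3 holds the lowest number of the three, and its gaps to both others lie beyond the scatter. Compound 4 `O=C(NCCNS(=O)(=O)c1ccc(-c2ccccc2OCc2ccccc2)s1)Nc1cc(C(F)(F)F)cc(C(F)(F)F)c1` carries benzyl in place of 3,4-dinitrophenyl on an oxygen on an aromatic ring. The closest guide is a 2.1-fold lower number from compound 2 to compound 3 (0.32 log units; beyond the scatter), since compound 2 carries 3-hydroxybenzyl at that place. The other guide, a 3.7-fold lower number from compound 1 to compound 3 (0.57 log units; beyond the scatter), is larger. Read backwards, both steps point to a modest rise in this assay once 3,4-dinitrophenyl leaves. The expected change is a 2.0-fold higher number from compound 3 to compound 4 (0.30 log units; within the scatter). Compound 4 is estimated at 3800 nM, with an expected range from 1800 nM to 8000 nM.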

Compound 4, half-maximal inhibitory concentration: 11400 nM
Compound 4: middle estimate off by 3.0-fold (0.48 log units), on the low side; the measured number lies above the stated range.
By their numbers in this assay, from the lowest: compound 3; then compounds 2, 1 and 4 (each within the scatter of the next, the first and the last beyond it).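

In this assay, going by these compounds alone, the change at this oxygen spans more than the earlier compounds showed, with a 6.0-fold higher number from compound 3 to compound 4 (0.78 log units; beyond the scatter) as the largest step at this position. A single hydroxy on the benzyl ring also counts, since hydrogen in its place gives a 2.9-fold higher number from compound 2 to compound 4 (0.45 log units; beyond the scatter), while a 1.6-fold higher number from compound 1 to compound 4 (0.21 log units; within the scatter) leaves benzyl and 4-hydroxycyclohexyl unseparated. Nothing available explains these steps.

From the compounds shown here alone, whether an amine or a carboxylic acid in place of the hydroxy of 3-hydroxybenzyl would match it stays open. So does whether one nitro group alone on the phenyl ring would hold the number of compound 3.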